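This account rests on a few compounds, and the source may have more. Where it says the series, first, only, none or still open, it means among the compounds named here.

Measured compounds

- Compound 1 `COc1ccc(/C=C/C(=O)/C=C/c2cc3ccccc3nc2Cl)cc1`: in a functional assay on HeLa cells (Homo sapiens) for cytotoxicity, read by MTT assay, with a stated time of 48 h (a lower number here means a stronger inhibitor, a higher number a weaker inhibitor), compound 1 gives > 10000 nM, which is a limit of the assay and not a number.
- Compound 2 `COc1ccc(/C=C/C(=O)/C=C/c2cc3ccccc3nc2Cl)c(OC)c1`: compound 2 gives > 10000 nM, again only a limit.
- Compound 3 `COc1ccc(/C=C/C(=O)/C=C/c2cc3ccccc3nc2Oc2ccccc2)cc1OC`: compound 3 gives > 10000 nM, also only a limit.

The change from compound 1 to compound 2 is methoxy in place of hydrogen on an aromatic carbon. Its size is a step that the two limits leave unreadable from compound 1 to compound 2; the step cannot be read because the limit of > 10000 nM in this assay, at which 3 of the 3 values shown sit, caps both ends. The difference between the cores of compound 1 and compound 3 is not broken down here.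

Compound 4 `COc1cc(OC)c(OC)cc1/C=C/C(=O)/C=C/c1cc2ccccc2nc1Oc1ccccc1` is not yet measured. It differs from compound 3 by methoxy in place of hydrogen on an aromatic carbon. Within the data shown here, this is the same kind of change as from compound 1 to compound 2, though the surroundings are not identical: in compound 4 the entering methoxy is also para to a methoxy group, which has no counterpart in compound 2.

In this assay the step is expected to be a step that the limit leaves unreadable from compound 3 to compound 4, resting on (the limit of > 10000 nM in this assay, at which 3 of the 3 values shown sit), where all three values sit. Compound 4 is therefore expected near 15000 nM, with a plausible range of 8000 nM to 50000 nM, and most likely reported only as a limit.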

Compound 4, half-maximal inhibitory concentration: 12200 nM
Compound 4: middle estimate off by 1.2-fold (0.09 log units), on the high side, and the stated range covers the measured number.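

In this assay compound 3 gives > 10000 nM, which is a limit of the assay and not a number. The step from compound 3 to compound 4 therefore cannot be read: the limit of > 10000 nM in this assay, at which 3 of the 4 values shown sit.

The compounds shown leave open how large the effect of methoxy in place of hydrogen on an aromatic carbon is in either pair, and whether any change to the shared core gives a stronger inhibitor.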